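Swapping Methyl for Methoxy: Expected Effect on Cell Toxicity

The source may hold more compounds than are shown below. What is called first, only, known or untested is meant among the compounds shown, and "the series" means these compounds.

Compound 1 `C=C[C@@](C)(/C=C/c1ccc(OCc2cn(-c3ccc(C)cc3)nn2)cc1)CCC=C(C)C` and compound 2 `C=C[C@@](C)(/C=C/c1ccc(OCc2cn(-c3ccc(OC)cc3)nn2)cc1)CCC=C(C)C` share one core and differ only in that (methoxy in place of methyl on an aromatic carbon). In a toxicity assay on RAW264.7 cells (Mus musculus) for cytotoxicity, read by MTT assay, with a stated time of 24 h (on this read-out higher numbers stand for weaker inhibition and lower numbers for stronger inhibition), compound 1 gives 86900 nM, while compound 2 gives 47400 nM. The step is a 1.8-fold lower number from compound 1 to compound 2 (0.26 log units; within the scatter). Compound 3 `C=C[C@@](C)(/C=C/c1ccc(OCc2cn(Cc3ccc(C)cc3)nn2)cc1)CCC=C(C)C` carries a different core: 4-methylbenzyl in place of 4-methylphenyl on an aromatic nitrogen. In this assay compound 3 gives 371000 nM; the steps are a 4.3-fold higher number from compound 1 to compound 3 (0.63 log units; beyond the scatter) and a 7.8-fold higher number from compound 2 to compound 3 (0.89 log units; beyond the scatter). Compound 4 `C=C[C@@](C)(/C=C/c1ccc(OCc2cn(Cc3ccc(OC)cc3)nn2)cc1)CCC=C(C)C` has not yet been measured and differs from compound 3 only in that (methoxy in place of methyl on an aromatic carbon), the same change seen between compound 1 and compound 2. Because the earlier instance gave a 1.8-fold lower number from compound 1 to compound 2 (0.26 log units; within the scatter), compound 4 is expected to show a comparably small step, a 1.5-fold lower number from compound 3 to compound 4 (0.19 log units; within the scatter). Compound 4 is therefore estimated at 240000 nM, most likely between 100000 nM and 600000 nM.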

Compound 4, half-maximal inhibitory concentration: 273000 nM
Estimate against measurement, compound 4: 1.1-fold (0.06 log units) below; the range from low to high includes it.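

The step for methoxy in place of methyl on the core of compound 3 is a 1.4-fold lower number from compound 3 to compound 4 (0.13 log units; within the scatter) in this assay, and it does not differ from the step on the core of compound 1: the same change on two cores in this assay, a 1.8-fold lower number (0.26 log units; within the scatter) from compound 1 to compound 2 and a 1.4-fold lower number (0.13 log units; within the scatter) from compound 3 to compound 4, 1.3-fold (0.13 log units) apart, within the scatter of two such steps. The larger steps come instead from the group on the aromatic nitrogen, a 5.8-fold higher number from compound 2 to compound 4 (0.76 log units; beyond the scatter) and a 3.1-fold higher number from compound 1 to compound 4 (0.50 log units; beyond the scatter). This shows that the change carries across these two cores as a step within the scatter, but it does not show that the change has any real effect, or that another core would behave the same way.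

On these data alone, it remains open whether a carboxylic acid or an amine on that aromatic carbon would give a step beyond the scatter. As far as these compounds go, what a longer chain on the aromatic nitrogen would do also remains open.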